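A few compounds are considered here, and "the series" means these few. Any claim that something is new, unique, unknown or untested is made for them only; others in the source may bear on it.

Measured compounds in a functional assay on A549 cells (Homo sapiens) for cytotoxicity, read by MTT assay, with a stated time of 48 h; on this read-out higher numbers stand for weaker inhibition and lower numbers for stronger inhibition:
compound 1 `C#CCSc1nnc(CC)n1N1C(=O)c2ccccc2C1=O`, a limit only: > 200000 nM
compound 2 `CCc1nnc(SCc2ccccc2)n1N1C(=O)c2ccccc2C1=O`, a limit only: > 200000 nM
compound 3 `CCc1nnc(SCC(=O)c2ccc(C)cc2)n1N1C(=O)c2ccccc2C1=O`, a limit only: > 200000 nM

Compound 2 stands on a limit of this assay and not on a number, at > 200000 nM. The two further values shown are likewise limits and not numbers. Hence the steps a step that the two limits leave unreadable from compound 1 to compound 2, a step that the two limits leave unreadable from compound 1 to compound 3 and a step that the two limits leave unreadable from compound 2 to compound 3 cannot be read in either direction, because the limit of > 200000 nM in this assay, at which 3 of the 3 values shown sit, holds for every value in the set; nothing in these data separates the three compounds.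

Compound 4 `CCCc1nnc(SCc2ccccc2)n1N1C(=O)c2ccccc2C1=O` differs from compound 2 by methyl in place of hydrogen on a saturated chain carbon, two bonds along the chain from an aromatic carbon, so that the ethyl on the shared core becomes propyl. Going by the values given here, no measured step bears on a change of this kind, and the steps that are known all run between limits, so no direction can be drawn from them. Compound 4 is therefore expected to sit where compound 2 sits, at the limit, a step that the limit leaves unreadable from compound 2 to compound 4 no larger than the scatter. Compound 4 is estimated at 300000 nM, with a range from 100000 nM to 1000000 nM.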

Compound 4, half-maximal inhibitory concentration: > 200000 nM
Compound 4: only a limit was reported; the forecaster's own chance of this, stated with the estimate: 85%; the middle value is on the limit's open side.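

Compound 4 also gives a limit and not a number, so no new step can be read between compound 2 and compound 4: the limit of > 200000 nM in this assay, at which 4 of the 4 values shown sit.

The compounds shown leave open whether any change on the shared core would give a readable value and separate these compounds.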